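Adding a methoxy group to a cytotoxic benzothiazole amide

The source may report more compounds than this note shows. Statements on the series, on what has been measured and on what is new or still open speak of the compounds shown alone.

Of the compounds shown here, three with a shared core have been tested in a functional assay on HepG2 cells (Homo sapiens) for cytotoxicity, read by MTT assay, with a stated time of 48 h; a lower number here means a stronger inhibitor, a higher number a weaker inhibitor. Compound 1 `COc1ccc(CNC(=O)CSc2nc3ccc(NC(=O)c4ccc(Cl)cc4)cc3s2)cc1` gives 7400 nM and compound 2 `COc1ccc(CNC(=O)CSc2nc3ccc(NC(=O)CCl)cc3s2)cc1` gives 2000 nM; the change between them, a 3.7-fold lower number from compound 1 to compound 2 (0.57 log units; beyond the scatter), swaps the group on the carbonyl carbon. For compound 3 `O=C(CSc1nc2ccc(NC(=O)c3ccc([N+](=O)[O-])cc3)cc2s1)NCc1ccccc1` only a limit of the assay is known, > 100000 nM. Compound 4 `COc1ccc(CNC(=O)CSc2nc3ccc(NC(=O)c4ccc([N+](=O)[O-])cc4)cc3s2)cc1` differs from compound 3 by methoxy in place of hydrogen on an aromatic carbon. Among the compounds with values here, no measured step addresses this change; the only measured step concerns another part of the molecule, so it gives no guide to direction or size. Compound 4 is therefore expected near the limit, an estimated 60000 nM with a range from 15000 nM to 200000 nM, which means an expected step of an at least 1.6-fold lower number from compound 3 to compound 4 (0.22 log units; that floor lies within the scatter).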

Compound 4, half-maximal inhibitory concentration: > 100000 nM
Compound 4: only a limit was reported; the forecaster's own chance of this, stated with the estimate: 50%; middle value at least 1.6-fold (0.22 log units) from the limit.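

In this assay, the methoxy step cannot be read, because compound 3 and compound 4 both stand at the same limit: the limit of > 100000 nM in this assay, at which 2 of the 4 values shown sit. With the 4-methoxybenzyl group in place, the group on the amide carbonyl still matters: nitro in place of chloro gives an at least 13-fold higher number from compound 1 to compound 4 (1.13 log units; beyond the scatter), and 4-nitrophenyl in place of chloromethyl gives an at least 50-fold higher number from compound 2 to compound 4 (1.69 log units; beyond the scatter). Methoxy therefore does not bring the nitro compound down to a readable value.

As far as these compounds go, what methoxy does in a compound with a readable value stays open. So does whether an amine in place of the nitro group would lower the number.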